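The compounds below may be only part of what the source reports. "The series", "measured", "known", "first", "only" and "open" are said of these compounds alone.

Two compounds share one core and differ only in the group on the saturated chain carbon bound to the amide-type nitrogen. Compound 1 `CN(C)CCN1CCN(C2=Nc3ccccc3C(CC(=O)NCc3ccccc3)N2c2ccc(-c3ccccc3)cc2)CC1` carries a benzyl group there; in a functional assay on cells (Homo sapiens) for cytotoxicity, read by MTT assay, with a stated time of 48 h (a higher number here means a weaker inhibitor, a lower number a stronger inhibitor), compound 1 gives 2390 nM. Compound 2 `CN(C)CCN1CCN(C2=Nc3ccccc3C(CC(=O)NCc3ccc(F)cc3)N2c2ccc(-c3ccccc3)cc2)CC1` carries a 4-fluorobenzyl group instead, and in this assay compound 2 gives 4000 nM. Within the data shown here, the step of a 1.7-fold higher number from compound 1 to compound 2 (0.22 log units; within the scatter) is the only measured step, and it is within the scatter. Among the two numbers, compound 2 has the highest, with compound 1 nearest to it and within the scatter of it.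

Compound 3 `CN(C)CCN1CCN(C2=Nc3ccccc3C(CC(=O)NCc3ccccn3)N2c2ccc(-c3ccccc3)cc2)CC1` takes the next step: pyridin-2-yl in place of 4-fluorophenyl on a saturated chain carbon bound to an amide-type nitrogen. Among the measured compounds shown here, the only measured step that bears on this, the step from compound 1 to compound 2, touched the same ring and was within the scatter, so no measured step describes a nitrogen entering this ring. On that footing no step beyond the scatter in this assay is expected, in either direction, which as a step means a 1.3-fold lower number from compound 2 to compound 3 (0.10 log units; within the scatter). Compound 3 is therefore estimated to give 3200 nM in this assay, within a range from 1200 nM to 8500 nM.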

Compound 3, half-maximal inhibitory concentration: > 5000 nM
Compound 3 was reported as a limit; the forecaster's own chance of this, stated with the estimate: 5%; middle value at least 1.5-fold (0.19 log units) from the limit.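

In this assay compound 3 is reported only as a limit of the assay and not as a number: the limit of > 5000 nM in this assay, at which 1 of the 3 values shown sits. Placing pyridin-2-yl instead of phenyl on a saturated chain carbon bound to an amide-type nitrogen gives an at least 2.0-fold higher number from compound 1 to compound 3 (0.32 log units; beyond the scatter). Among these compounds, this is the first step at this place that clears the scatter, so the group here can change the result in this assay even though the fluoro step earlier did not, while the other new step, an at least 1.2-fold higher number from compound 2 to compound 3 (0.09 log units; that floor lies within the scatter), shows no clear change on its own because of what this limit hides: the limit of > 5000 nM in this assay, at which 1 of the 3 values shown sits.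

How far compound 3 lies past its limit stays open, and with a single ring containing nitrogen, the compounds shown cannot tell whether the hetero atom itself or something else about pyridin-2-yl goes with the higher number. Also open, as far as these compounds go, is what a cyclohexyl group, an amine, a carboxylic acid or a longer chain would do at this place on the saturated chain carbon.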